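Compound 3 and the Dichlorophenyl Swap

A few compounds are considered here, and "the series" means these few. Any claim that something is new, unique, unknown or untested is made for them only; others in the source may bear on it.

Measured in a functional assay on HCT-116 cells (Homo sapiens) for cytotoxicity, read by MTT assay, with a stated time of 48 h; on this read-out higher numbers stand for weaker inhibition and lower numbers for stronger inhibition:
- compound 1 `COc1cc(/C=C/C(=O)C2=C(/C=C/c3ccc(O)c(OC)c3)NC(=S)NC2c2ccccc2O)ccc1O`: 100000 nM
- compound 2 `COc1cc(/C=C/C(=O)C2=C(/C=C/c3ccc(O)c(OC)c3)NC(=S)NC2c2ccc(N(C)C)cc2)ccc1O`: 12500 nM

Compound 2 holds the lower of the two numbers, at 12500 nM. Compound 3 `COc1cc(/C=C/C(=O)C2=C(/C=C/c3ccc(O)c(OC)c3)NC(=S)NC2c2c(Cl)cccc2Cl)ccc1O` carries 2,6-dichlorophenyl in place of 4-(dimethylamino)phenyl on a saturated ring carbon. Among the measured compounds shown here, the only measured step at this carbon is modest, an 8.0-fold lower number from compound 1 to compound 2 (0.90 log units; beyond the scatter). For the measured compounds named here, no measured compound carries 2,6-dichlorophenyl, so the direction stays open, and no step beyond the scatter is expected in this assay. The expected step is a 1.2-fold higher number from compound 2 to compound 3 (0.08 log units; within the scatter). For compound 3 the estimated value is 15000 nM, with an expected range of 4000 nM to 60000 nM.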

Compound 3, half-maximal inhibitory concentration: 50000 nM
Estimate against measurement, compound 3: 3.3-fold (0.52 log units) below; low and high end bracket the measured number.
By their numbers in this assay, from the lowest: compound 2; then compounds 3 and 1 (each within the scatter of the next).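

In this assay, the saturated ring carbon proves sensitive to the swap to 2,6-dichlorophenyl, with a 4.0-fold higher number from compound 2 to compound 3 (0.60 log units; beyond the scatter), so the lower number of compound 2 does not carry over to this group. Against 2-hydroxyphenyl the same group gives a 2.0-fold lower number from compound 1 to compound 3 (0.30 log units; within the scatter), a step that does not separate the two. No measurement shown here explains these differences. Still open, from the compounds shown here alone, is whether a primary amine or a single chlorine on the phenyl ring would match 4-(dimethylamino)phenyl in compound 2.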